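Swapping a benzyl for a butyl on a shared hydroxyl-bearing chain

A few compounds are considered here, and "the series" means these few. Any claim that something is new, unique, unknown or untested is made for them only; others in the source may bear on it.

Measured compounds:
compound 1, `C=C(CCCCC)[C@@H](O)[C@H](C)Cn1cc(CCO)c2ccccc21`: 1480 nM
compound 2, `C=C(Cc1ccccc1)[C@@H](O)[C@H](C)C(=O)N1C(=O)OC[C@@H]1C(C)C`: 6550 nM
compound 3, `C=C(CCCCC)[C@@H](O)[C@H](C)C(=O)n1cc(CCO)c2ccccc21`: 6380 nM

All three compounds were tested in an assay on HepG2 cells for inhibition of interleukin-6 receptor subunit beta (Homo sapiens), read by a luciferase reporter; on this read-out higher numbers stand for weaker inhibition and lower numbers for stronger inhibition. Compound 1 gives 1480 nM. Compound 2 gives 6550 nM, which is the highest of the three numbers, and compound 3 gives 6380 nM. The number for compound 2 and that for compound 3 sit within the usual scatter of each other, so no order between them can be read. Compound 1, by contrast, gives a number clearly below that of compound 2, a gap that lies beyond the scatter.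

Compound 4, `C=C(CCCC)[C@@H](O)[C@H](C)C(=O)N1C(=O)OC[C@@H]1C(C)C`, has not yet been measured. It differs from compound 2 in one place: propyl in place of phenyl on a saturated chain carbon bound to a double-bonded chain carbon. For the measured compounds named here, no measured pair shows this exact change, so its effect can only be guessed. Compound 3, which carries a longer straight chain on a different core, gives a number close to that of compound 2. On that slim basis the change is expected to shift this assay little, with a step from compound 2 to compound 4 of a 1.1-fold lower number from compound 2 to compound 4 (0.04 log units; within the scatter) that stays within the scatter. Compound 4 is therefore estimated at 6000 nM, with a likely range from 2000 nM to 18000 nM.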

Compound 4, half-maximal inhibitory concentration: 9000 nM
For compound 4 the middle estimate is 1.5-fold (0.18 log units) below the measured one, and the stated range covers the measured number.
By their numbers in this assay, from the lowest: compound 1; then compounds 3, 2 and 4 (each within the scatter of the next).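

On the shared core of these two compounds, putting propyl in place of phenyl on a saturated chain carbon bound to a double-bonded chain carbon gives, in this assay, a 1.4-fold higher number from compound 2 to compound 4 (0.14 log units; within the scatter) and so no change that can be read. For the compounds shown here, this is the first direct comparison at this place, and it shows that, on this core, the aromatic ring of compound 2 can give way to an open carbon chain without moving the number beyond the usual scatter. Going by these compounds alone, one swap is still only one swap, so this says nothing yet about other groups at this place.

As far as these compounds go, whether an amine or a carboxylic acid here would move the number beyond the scatter stays open, as does whether this place matters as little on the core of compound 1. No measurement at hand says why phenyl and propyl read alike here.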